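Primary amide against dimethylamide in a whole-animal test

This account rests on a few compounds, and the source may have more. Where it says the series, first, only, none or still open, it means among the compounds named here.

Of the compounds shown here, three sharing one core have been measured in a functional assay on the whole organism with Mus musculus as the target; on this read-out lower numbers stand for an effect already at smaller amounts and higher numbers for an effect only at larger amounts of compound. Compound 1 `CN(C)C(=O)/C=C1\CCc2c(F)cc(F)cc21` gives 50 mg/kg. Compound 3 `NC(=O)/C=C1\CCc2ccc(F)cc21` gives 56 mg/kg. Compound 2 `CCCNC(=O)/C=C1\CCc2ccc(F)cc21` gives only a limit of the assay, > 100 mg/kg, as the evidence states: the limit of > 100 mg/kg in this assay, at which 1 of the 3 values shown sits.

Compound 3 stands among the two numbers obtained; compound 1 gives a number that lies within the scatter of that of compound 3, and the third value is a limit. Among the compounds with values here, the one measured step, an at least 1.7-fold lower number from compound 2 to compound 3 (0.25 log units; that floor lies within the scatter), removes a propyl from the amide nitrogen and moves the number downward, at least to an extent that lies within the scatter.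

Compound 4 `CN(C)C(=O)/C=C1\CCc2ccc(F)cc21` differs from compound 3 at the same amide nitrogen: dimethylamino in place of amino on a carbonyl carbon. The step from compound 2 to compound 3 bears on it, since both alter the substituent on the amide nitrogen, though in the opposite sense. Compound 1, which already carries the dimethylamino group, gives a number within the scatter of that of compound 3. In this assay, therefore, no step beyond the scatter is expected, and the estimated step from compound 3 to compound 4 is a 1.2-fold lower number from compound 3 to compound 4 (0.09 log units; within the scatter). Compound 4 is expected to give about 45 mg/kg, between 22 mg/kg and 90 mg/kg.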

Compound 4, dose for half-maximal effect: > 100 mg/kg
Compound 4 ended at the assay's limit; the forecaster's own chance of this, stated with the estimate: 15%; at least 2.2-fold (0.34 log units) between middle value and limit.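

Replacing amino with dimethylamino on the carbonyl carbon gives in this assay an at least 1.7-fold higher number from compound 3 to compound 4 (0.25 log units; that floor lies within the scatter). On the shared core of compound 3, amides with a propyl or two methyl groups on the nitrogen now both end at a limit and only the unsubstituted amide gives a number, but the printed floors for the steps to both limits lie within the scatter, so this is a hint rather than an established loss. Compound 1 goes against any simple rule that dimethylamino costs the effect, as it carries that group and still gives a number, and hydrogen in place of fluoro on an aromatic carbon gives an at least 2.0-fold higher number from compound 1 to compound 4 (0.30 log units; that floor lies within the scatter), so the aromatic fluoro now joins the amide nitrogen as an open question, again with a floor inside the scatter.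

The step between compound 2 and compound 4 cannot be read, as both values are limits: the limit of > 100 mg/kg in this assay, at which 2 of the 4 values shown sit.

Still open, from the compounds shown here alone, is how far beyond the limit these compounds lie, and whether a methylamino group, with a single methyl on the amide nitrogen, would behave like amino or like dimethylamino on this core.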